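The source may report more compounds than this note shows. Statements on the series, on what has been measured and on what is new or still open speak of the compounds shown alone.

Compound 3 `Cc1c(CC(O)CO)n(COCC[Si](C)(C)C)c(=O)[nH]c1=O` is examined in a functional assay on MCF7 cells (Homo sapiens) for antiproliferative activity, read by MTT assay, with a stated time of 72 h; on this read-out lower numbers stand for stronger inhibition and higher numbers for weaker inhibition. In this assay compound 3 gives > 100000 nM, which is a limit of the assay rather than a measured number. Compound 2 `C[Si](C)(C)CCOCn1c(CC(O)CO)cc(=O)[nH]c1=O` also reaches a limit: in this assay compound 2 gives > 100000 nM. Among the measured compounds shown here, the single change measured between these two, a step that the two limits leave unreadable from compound 2 to compound 3, cannot be sized, as the limit of > 100000 nM in this assay, at which 2 of the 3 values shown sit, shows both values resting at that limit. Compound 1 `COCn1c(=O)[nH]c(CC(COCc2ccccc2)COCc2ccccc2)c(C)c1=O` differs from compound 3 in more than one place, and in this assay compound 1 gives 21600 nM. Compound 4 `COCn1c(CC(O)CO)c(C)c(=O)[nH]c1=O` is not yet measured. It differs from compound 3 by a hydrogen atom in place of a group of 5 heavy atoms (4 carbon, 1 silicon; no ring), on a saturated chain carbon bound to an oxygen on a saturated carbon. For the measured compounds named here, no measured step covers this change, and the one measured step is unreadable. Compound 4 is therefore estimated at 150000 nM, with a range from 30000 nM to 800000 nM. The expected step is a step that the limit leaves unreadable from compound 3 to compound 4, most likely again ending at a limit.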

Compound 4, half-maximal inhibitory concentration: > 100000 nM
Compound 4 ended at the assay's limit (the forecaster's own chance of this, stated with the estimate: 70%); the middle value lies beyond the limit too.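

Compound 3 and compound 4 both rest at a limit of this assay rather than at a measured number, so the step between them cannot be read: the limit of > 100000 nM in this assay, at which 3 of the 4 values shown sit.

The compounds shown leave open whether replacing the group of 5 heavy atoms with hydrogen changes the inhibition at all.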